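Cyclopropylmethyl ether in place of difluoroethyl ether

The source may hold more compounds than are shown below. What is called first, only, known or untested is meant among the compounds shown, and "the series" means these compounds.

Compound 1: `O=C(O)Cn1nc(Cc2nc3cc(Cl)c(OCC(F)F)cc3[nH]2)c2ccccc2c1=O` with 15 nM
Compound 2: `COc1cc(OC)c(NC(=O)Cc2cn(C)c3ccccc23)cc1Cl` with 19200 nM
Compound 3: `CC(C(=O)O)c1nn(Cc2cn3cc(OCC4CC4)c(C(F)(F)F)cc3n2)c2ccccc2c1=O` with 51 nM

Of the compounds shown here, three have been measured in a functional assay on CHO cells for antagonist activity at sphingosine 1-phosphate receptor 2 (Homo sapiens), read by GTPgammaS binding; a lower number here means a stronger inhibitor, a higher number a weaker inhibitor. Compound 1 gives the lowest of the three numbers, at 15 nM. Its nearest neighbour is compound 3, which in this assay gives 51 nM, a gap that lies beyond the scatter; compound 2, at 19200 nM, lies far beyond both. Compound 3 differs from compound 1 in its core and in the acid-bearing chain as well as in the ether, so no single change can be read from that pair.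

Compound 4 is `O=C(O)Cn1nc(Cc2nc3cc(Cl)c(OCC4CC4)cc3[nH]2)c2ccccc2c1=O`. It keeps the core, the chlorine and the acetic acid chain of compound 1 and changes only the ether: cyclopropyl in place of difluoromethyl on a saturated chain carbon bound to an oxygen on an aromatic ring. The two groups are counted alike in heavy atoms, donors, acceptors and charge. Going by the values given here, nothing among the measured compounds isolates this change, so the expectation for the step from compound 1 to compound 4 is one of no movement beyond the scatter, in either direction: a 1.2-fold higher number from compound 1 to compound 4 (0.08 log units; within the scatter) is the expected step. In this assay compound 4 is accordingly expected to give about 18 nM, within a range from 6 nM to 55 nM.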

Compound 4, half-maximal inhibitory concentration: 25 nM
The estimate for compound 4 lay 1.4-fold (0.14 log units) below the measured number, and the stated range covers the measured number.
By their numbers in this assay, from the lowest: compounds 1 and 4 (each within the scatter of the next); then compound 3; then compound 2.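

In this assay, going by these compounds alone, this is the first change that can be read on its own. The earlier compounds shown here differ in several places at once. Cyclopropyl in place of difluoromethyl on a saturated chain carbon bound to an oxygen on an aromatic ring gives a 1.7-fold higher number from compound 1 to compound 4 (0.22 log units; within the scatter). With the core, the chlorine and the acetic acid chain held fixed, the two groups therefore cannot be told apart in this assay, and in this pair the fluorine atoms of the 2,2-difluoroethoxy group are not required for a number in the range of compound 1. No independent measurement bearing on why the two groups read alike is available here.

The compounds shown leave open how much this position tolerates beyond these two groups, for instance a plain methoxy, a longer chain such as n-butoxy, or an amine in place of the ether. They also leave open whether the same exchange would read the same way on the core and acid-bearing chain of compound 3, where the cyclopropylmethoxy group sits in a different setting.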